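Fluorophenyl position swap on the shared core

The source may hold more compounds than are shown below. What is called first, only, known or untested is meant among the compounds shown, and "the series" means these compounds.

Compound 3 `COc1cc2c(Oc3ccc(NC(=O)c4cc(-c5ccc(F)cc5)ccn4)cc3F)ccnc2cc1OCCCN1CCN(C)CC1` gives 510 nM in a functional assay on MKN-45 cells (Homo sapiens) for cytotoxicity, read by MTT assay, with a stated time of 72 h (a higher number here means a weaker inhibitor, a lower number a stronger inhibitor), the highest of the three numbers in hand. Compound 1 `COc1cc2c(Oc3ccc(NC(=O)c4cc(-c5ccccc5)ccn4)cc3F)ccnc2cc1OCCCN1CCN(C)CC1` gives 150 nM, and compound 2 `COc1cc2c(Oc3ccc(NC(=O)c4cc(-c5ccccc5F)ccn4)cc3F)ccnc2cc1OCCCN1CCCCC1` gives 180 nM. Within the data shown here, the single measured step touching this ring, a 3.4-fold higher number from compound 1 to compound 3 (0.53 log units; beyond the scatter), concerns adding a fluoro rather than moving it, so it bears only loosely on the present change. Compound 4 `COc1cc2c(Oc3ccc(NC(=O)c4cc(-c5ccccc5F)ccn4)cc3F)ccnc2cc1OCCCN1CCN(C)CC1` differs from compound 3 by 2-fluorophenyl in place of 4-fluorophenyl on an aromatic carbon. The same 2-fluorophenyl group is held by compound 2, which differs from compound 4 elsewhere in the molecule. The value of compound 2, 180 nM, is therefore a guide, not a measurement of the step. A drop is therefore expected, a 2.6-fold lower number from compound 3 to compound 4 (0.41 log units; beyond the scatter), toward the values of compound 1 and compound 2. The estimate for compound 4 is 200 nM, with a range of 90 nM to 450 nM.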

Compound 4, half-maximal inhibitory concentration: 150 nM
Compound 4: the middle estimate sits 1.3-fold (0.12 log units) above what was measured, within the range that was stated.
By their numbers in this assay, from the lowest: compounds 1, 4 and 2 (each within the scatter of the next); then compound 3.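

In this assay the place of the fluoro on the phenyl ring counts: 2-fluorophenyl in place of 4-fluorophenyl gives a 3.4-fold lower number from compound 3 to compound 4 (0.53 log units; beyond the scatter) and, against the unsubstituted phenyl, the record is no change at the digits printed from compound 1 to compound 4 (within the scatter) so a fluoro is tolerated in the 2-position of these two. On the 2-fluorophenyl background, 4-methylpiperazin-1-yl in place of piperidin-1-yl gives a 1.2-fold lower number from compound 2 to compound 4 (0.08 log units; within the scatter) and the two chain ends cannot be told apart here. Nothing at hand accounts for the gap between the two fluoro placements. Going by these compounds, whether a chlorophenyl or a methoxyphenyl group in this place would read with compound 4 or with compound 3 stays open.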